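A few compounds are considered here, and "the series" means these few. Any claim that something is new, unique, unknown or untested is made for them only; others in the source may bear on it.

Values in an in vivo ADME assay on the whole organism (strain 129/SvEvBrd x C57BL/6) for pharmacokinetics, with Mus musculus as the target, at a dose of 1 mg/kg by the intravenous route (a higher number here means faster removal of the compound, a lower number slower removal), so far:
- Compound 1 `CC(=O)c1ncc([C@@H](O)[C@H](O)[C@H](O)CO)s1` gives 11.7 mL/min/kg
- Compound 2 `CCc1[nH]c(C(C)=O)nc1[C@@H](O)[C@H](O)[C@H](O)CO` gives 17.3 mL/min/kg
- Compound 3 `OC[C@@H](O)[C@@H](O)[C@H](O)c1c[nH]c(-c2cocn2)n1` gives 16.6 mL/min/kg

The three values lie within the scatter of one another, so compound 3 stands level with compound 1 and compound 2. Compound 4 `Cn1cnc(-c2nc([C@@H](O)[C@H](O)[C@H](O)CO)c[nH]2)c1` differs from compound 3 by 1-methyl-1H-imidazol-4-yl in place of 1,3-oxazol-4-yl on an aromatic carbon with 1-methyl-1H-imidazol-4-yl in place of 1,3-oxazol-4-yl on an aromatic carbon. Among the measured compounds shown here, no measured pair differing in one place shows what such a change does, so the expectation rests on compound 3 at 16.6 mL/min/kg and on the narrow spread of the three values. No step beyond the scatter is expected in this assay, and the estimated 1.0-fold lower number from compound 3 to compound 4 (0.02 log units; within the scatter) is a small one. For compound 4 the estimated clearance is 16 mL/min/kg with an expected range from 8 mL/min/kg to 32 mL/min/kg in this measurement.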

Compound 4, clearance: 9.1 mL/min/kg
The estimate for compound 4 lay 1.8-fold (0.25 log units) above the measured number, and the stated range covers the measured number.
By their numbers in this assay, from the lowest: compounds 4, 1, 3 and 2 (each within the scatter of the next).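

In this assay, among the compounds shown here, the first single-place comparison at this position, on an aromatic carbon between two ring nitrogen atoms, gives a 1.8-fold lower number from compound 3 to compound 4 (0.26 log units; within the scatter) for 1-methyl-1H-imidazol-4-yl in place of 1,3-oxazol-4-yl. This position therefore takes an exchange of one five-membered aromatic ring for another without a step beyond the scatter. No measurement at hand bears on what lies behind this result. On these data alone, whether an amine, a carboxylic acid or a longer chain at this position would move clearance beyond the scatter stays open.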